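Furan-3-yl for ethynyl on two nucleoside cores

The compounds below may be only part of what the source reports. "The series", "measured", "known", "first", "only" and "open" are said of these compounds alone.

Measured so far:
compound 1 `CN(C)c1ncnc2c1c(-c1ccoc1)cn2[C@@H]1O[C@H](CO)[C@@H](O)[C@H]1O` gives 14900 nM in a functional assay on K562 cells (Homo sapiens), read by MTT assay, with a stated time of 72 h; a higher number here means a weaker inhibitor, a lower number a stronger inhibitor
compound 2 `C#Cc1cn([C@@H]2O[C@H](CO)[C@@H](O)[C@H]2O)c2ncnc(N(C)C)c12` gives 260 nM in this assay
compound 3 `C#Cc1cn([C@@H]2O[C@H](CO)[C@@H](O)[C@H]2O)c2nc(N)nc(OC)c12` gives > 20000 nM in this assay

The value of compound 3 is a limit of the assay and not a number. Of the three values shown, one sits at this limit (the limit of > 20000 nM in this assay, at which 1 of the 3 values shown sits).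

Compound 2 and compound 1 share a core and differ in one place (furan-3-yl in place of ethynyl on an aromatic carbon). This change made the step of a 57-fold higher number from compound 2 to compound 1 (1.76 log units; beyond the scatter), so on this core the furan-3-yl compound is the much weaker inhibitor.

Compound 3 carries a different core from compound 2; the difference between the two cores is not broken down here. Compound 4 `COc1nc(N)nc2c1c(-c1ccoc1)cn2[C@@H]1O[C@H](CO)[C@@H](O)[C@H]1O` is not yet measured in this assay. It differs from compound 3 in the same way (furan-3-yl in place of ethynyl on an aromatic carbon), and the place line is the same word for word, so this is the same change as that from compound 2 to compound 1.

The expectation for compound 4 rests on two points: the value of compound 3, which already sits at the limit > 20000 nM, and the earlier step of a 57-fold higher number from compound 2 to compound 1 (1.76 log units; beyond the scatter), which went to weaker inhibition. Compound 4 is therefore expected to lie at or beyond the limit, with an expected step that the limit leaves unreadable from compound 3 to compound 4 from compound 3. Compound 4 is estimated at 200000 nM, with a range from 30000 nM to 1000000 nM, and the assay will most likely again report only a limit for compound 4.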

Compound 4, half-maximal inhibitory concentration: > 20000 nM
Compound 4 gave a limit, no number; the forecaster's own chance of this, stated with the estimate: 90%; the middle value is on the limit's open side.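

Compound 4 gives > 20000 nM in this assay as a limit and not a number. Compound 3 also gives only a limit, so the step between compound 3 and compound 4 cannot be read, since both values are limits of the assay: the limit of > 20000 nM in this assay, at which 2 of the 4 values shown sit.
The compounds shown leave open whether furan-3-yl in place of ethynyl weakens inhibition on the core of compound 3 as it does on the core of compound 2.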